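The compounds below may be only part of what the source reports. "The series", "measured", "known", "first", "only" and "open" are said of these compounds alone.

In a functional assay on HCT-116 cells (Homo sapiens) for inhibition, read by MTT assay, with a stated time of 48 h (on this read-out lower numbers stand for stronger inhibition and higher numbers for weaker inhibition), compound 1 `COc1ccc(CNc2cc(OC)c(OC)c(OC)c2)cc1[N+](=O)[O-]` gives 18200 nM, compound 2 `C/C=C/C(=O)N(Cc1ccc(OC)c(OC)c1)c1cc(OC)c(OC)c(OC)c1` gives 32800 nM and compound 3 `COc1ccc(CNc2cc(OC)c(OC)c(OC)c2)cc1Br` gives 48100 nM, so the last two lie within the scatter of each other. Compound 4 `C/C=C/C(=O)N(Cc1ccc(OC)c(Br)c1)c1cc(OC)c(OC)c(OC)c1` departs from compound 3 by one change on a nitrogen on an aromatic ring: (prop-1-en-1-yl)carbonyl in place of hydrogen on a nitrogen on an aromatic ring. Among the measured compounds shown here, the only measured step, a 2.6-fold higher number from compound 1 to compound 3 (0.42 log units; beyond the scatter), is modest and puts bromo in place of nitro on an aromatic carbon, so it says little about this nitrogen. Compound 2, which also carries (prop-1-en-1-yl)carbonyl on a nitrogen, gives 32800 nM, so no step beyond the scatter is expected in this assay. The expected step is a 1.6-fold lower number from compound 3 to compound 4 (0.21 log units; within the scatter). For compound 4 the estimate is 30000 nM, with an expected range from 11000 nM to 70000 nM.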

Compound 4, half-maximal inhibitory concentration: 2800 nM
Compound 4: the middle estimate sits 11-fold (1.03 log units) above what was measured, and the stated range ends above it.
By their numbers in this assay, from the lowest: compound 4; then compounds 1, 2 and 3 (each within the scatter of the next, the first and the last beyond it).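

Placing (prop-1-en-1-yl)carbonyl on the nitrogen gives a 17-fold lower number from compound 3 to compound 4 (1.23 log units; beyond the scatter) in this assay, so this nitrogen can strongly change the read-out, which the earlier step could not show. Bromo in place of methoxy gives a 12-fold lower number from compound 2 to compound 4 (1.07 log units; beyond the scatter), so with this group on the nitrogen, the change on the aromatic carbon also carries a large step. From the compounds shown here alone, whether the double bond matters remains open, as a saturated butanoyl group on the nitrogen would test that. Nothing measured here explains either step.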